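The compounds below may be only part of what the source reports. "The series", "measured", "known", "first", "only" and "open" are said of these compounds alone.

Of the compounds shown here, three have been tested in a functional assay on MCF7 cells (Homo sapiens) for cytotoxicity, read by MTT assay, with a stated time of 72 h; on this read-out higher numbers stand for lower toxicity in this test and lower numbers for higher toxicity in this test.

Compound 1, `COc1ccc(CNc2nc([SeH])nc3ccccc23)cc1`, gives > 100000 nM, which is a limit of the assay and not a number.
Compound 2, `Sc1nc(NCc2ccccc2)c2ccccc2n1`, gives > 100000 nM, again a limit rather than a number.
Among the measured compounds shown here, compound 3, `CCCCC[Se]c1nc(NCc2ccccc2)c2ccccc2n1`, gives 99400 nM, the only true number among the three.

Compound 3 therefore stands alone as a measured value, while compound 1 and compound 2 sit at the top limit of the measurement (the limit of > 100000 nM in this assay, at which 2 of the 3 values shown sit). For the measured compounds named here, the one step that can be read between measured compounds, a number no higher from compound 2 to compound 3 (the limit leaves the size open), runs from a limit to a number that lies almost on that limit, so its size cannot be read.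

Compound 4, `[SeH]c1nc(NCc2ccccc2)c2ccccc2n1`, differs from compound 3 by hydrogen in place of pentyl on a selenium. Going by the values given here, this change reverses much of the step from compound 2 to compound 3, the only measured step that bears on it, and that step showed no readable movement. No shift beyond the usual scatter is expected.

Because compound 3 gives 99400 nM, compound 4 is expected to give 100000 nM, with a range from 50000 nM to 200000 nM, and the step from compound 3 to compound 4 is estimated as a 1.0-fold higher number from compound 3 to compound 4 (0.00 log units; within the scatter). For compound 4 a result reported only as a limit is considered likely.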

Compound 4, concentration lethal to 50% of the cells: > 100000 nM
Compound 4: no number, only a limit; the forecaster's own chance of this, stated with the estimate: 65%; the middle value sits exactly at the limit.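

Among the compounds shown here, removing the pentyl from the selenium in this assay gives a number no lower from compound 3 to compound 4 (the limit leaves the size open), so compound 3 remains the only compound here with a true number, and that number lies almost on the limit. The steps to compound 4 from compound 2 and from compound 1 cannot be read, since both ends of each are limits, so neither swapping sulfur for selenium nor removing the methoxy shows any effect here. With hydrogen on the selenium, the series gathers even more tightly at one end of the scale: the limit of > 100000 nM in this assay, at which 3 of the 4 values shown sit.

The compounds shown leave open whether any group on the selenium can bring the number clearly down from the limit, for example a longer chain such as octyl, a benzyl group or a chain ending in an amine. They also leave open whether the same pentyl on sulfur would give a result like that of compound 3, which would show whether the selenium matters once a chain is attached.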